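A few compounds are considered here, and "the series" means these few. Any claim that something is new, unique, unknown or untested is made for them only; others in the source may bear on it.

Measured in a functional assay on HCT-116 cells (Homo sapiens) for inhibition, read by MTT assay, with a stated time of 72 h; a higher number here means a weaker inhibitor, a lower number a stronger inhibitor:
- compound 1 `COc1cc(Oc2cccc(Nc3ccccc3)c2)cc(OC)c1CNCc1ccccc1`: 4070 nM
- compound 2 `COc1ccc(CCCNCc2c(OC)cc(Oc3ccc(Nc4ccccc4)cc3)cc2OC)cc1`: 3230 nM
- compound 3 `COc1cc(Oc2cccc(Nc3ccccc3)c2)cc(OC)c1CNCCNC(C)=O`: 18200 nM

Compound 3 has the highest number of the three, which makes it the weakest inhibitor so far. Compound 4 `COc1cc(Oc2cccc(Nc3ccccc3)c2)cc(OC)c1CNC(C)C` is still unmeasured. It carries isopropyl in place of 2-acetamidoethyl on an amine nitrogen. Among the measured compounds shown here, one measured step bears on this change: a 4.5-fold higher number from compound 1 to compound 3 (0.65 log units; beyond the scatter). There an acetamido-bearing group came in and the number rose. Here such a group leaves, so a move of similar size toward a lower number is expected in this assay. For the measured compounds named here, no measured compound carries isopropyl, so this expectation is loose. The expected step is a 2.8-fold lower number from compound 3 to compound 4 (0.45 log units; beyond the scatter). The estimate for compound 4 is 6500 nM, with an expected range of 2500 nM to 16000 nM.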

Compound 4, half-maximal inhibitory concentration: > 20000 nM
Compound 4 ended at the assay's limit; the forecaster's own chance of this, stated with the estimate: 3%; at least 3.0-fold (0.48 log units) between middle value and limit.
By their numbers in this assay, from the lowest: compounds 2 and 1 (each within the scatter of the next); then compound 3. At a limit, above all of these: compound 4.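

In this assay compound 4 reads only as a limit, not as a number: the limit of > 20000 nM in this assay, at which 1 of the 4 values shown sits. Putting isopropyl in place of benzyl on this amine nitrogen weakens inhibition (an at least 4.9-fold higher number from compound 1 to compound 4 (0.69 log units; beyond the scatter)), so the activity of compound 1 needs more than the absence of the acetamido group. Against the 2-acetamidoethyl group, no difference can be read (an at least 1.0-fold higher number from compound 3 to compound 4 (0.04 log units; that floor lies within the scatter)), since that floor lies within the scatter. On these data alone, what stays open is whether the benzyl ring itself matters: a cyclohexylmethyl group or a longer straight alkyl chain on this nitrogen would test that.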